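Two Limit Values and an Untested Dinitrophenyl Analogue

The source may report more compounds than this note shows. Statements on the series, on what has been measured and on what is new or still open speak of the compounds shown alone.

Compound 1 `N#CC1=C(N)Oc2c(N)cc3nc4ccccc4nc3c2C12C(=O)N(Cc1cnnn1-c1ccc([N+](=O)[O-])cc1)c1ccccc12`: in an ADME assay on HUVEC cells (Homo sapiens) for antiproliferative activity, read by MTT assay, with a stated time of 48 h (on this read-out lower numbers stand for stronger inhibition and higher numbers for weaker inhibition), compound 1 gives > 50000 nM, a limit of the assay.
Compound 2 `Cc1ccc(-n2nncc2CN2C(=O)C3(C(C#N)=C(N)Oc4c(N)cc5nc6ccccc6nc5c43)c3ccccc32)cc1Cl`: in this assay compound 2 gives > 50000 nM, also a limit.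

Compound 2 thus stands at the edge of what this assay can report. Because both measured values sit at the limit (the limit of > 50000 nM in this assay, at which 2 of the 2 values shown sit), the step that the two limits leave unreadable from compound 1 to compound 2 cannot be read. Compound 3 `N#CC1=C(N)Oc2c(N)cc3nc4ccccc4nc3c2C12C(=O)N(Cc1cnnn1-c1ccc([N+](=O)[O-])cc1[N+](=O)[O-])c1ccccc12` differs from compound 2 in one place: 2,4-dinitrophenyl in place of 3-chloro-4-methylphenyl on an aromatic nitrogen. No readable step on this aromatic nitrogen exists, so no direction can be drawn. Compound 3 is expected to remain at the limit, a step that the limit leaves unreadable from compound 2 to compound 3. The estimate for compound 3 is 80000 nM, ranging from 20000 nM to 300000 nM.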

Compound 3, half-maximal inhibitory concentration: > 50000 nM
Compound 3: only a limit was reported; the forecaster's own chance of this, stated with the estimate: 85%; the middle value is on the limit's open side.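

Compound 3 also gives only a limit, so no step among compound 1, compound 2 and compound 3 can be read: the limit of > 50000 nM in this assay, at which 3 of the 3 values shown sit.

From the compounds shown here alone, whether any group on that aromatic nitrogen can bring the shared core to a measurable value in this assay stays open.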